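A few compounds are considered here, and "the series" means these few. Any claim that something is new, unique, unknown or untested is made for them only; others in the source may bear on it.

Three compounds have been measured in a functional assay on CCRF-CEM cells (Homo sapiens) for cytotoxicity, read by MTT assay, with a stated time of 72 h; a higher number here means a weaker inhibitor of growth, a lower number a stronger inhibitor of growth:

compound 1, `C=CCOC(=O)Nc1ccc([Se]C#N)cc1`, gives 9200 nM
compound 2, `O=C(Nc1ccc([Se][Se]c2ccc(NC(=O)OCc3ccccc3)cc2)cc1)OCc1ccccc1`, gives 6400 nM
compound 3, `N#C[Se]c1ccc(NC(=O)OCC2=Cc3ccccc3S2(=O)=O)cc1`, gives 3300 nM

Compound 1 has the highest of the three numbers. Compound 2 sits within the scatter of compound 1, so the two cannot be told apart on these data. Compound 3 lies beyond the scatter on the lower side of compound 1, so of that pair compound 3 is the stronger inhibitor of growth. Compound 4, `CCCCCCOC(=O)Nc1ccc([Se]C#N)cc1`, has not yet been measured. It differs from compound 1 in one place: pentyl in place of vinyl on a saturated chain carbon bound to an oxygen next to a carbonyl group. For the measured compounds named here, no pair of measured compounds shows a step of this kind, so the numbers in hand give no direct guide to its size. A modest effect is expected in this assay, with the direction uncertain, and it may well stay within the scatter. The expected step from compound 1 to compound 4 is a 1.4-fold lower number from compound 1 to compound 4 (0.15 log units; within the scatter). For compound 4 the estimated value is 6500 nM, with a range from 2500 nM to 18000 nM.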

Compound 4, concentration for 50% growth inhibition: 19700 nM
Compound 4: middle estimate off by 3.0-fold (0.48 log units), on the low side; the measured number lies above the stated range.
By their numbers in this assay, from the lowest: compounds 3, 2 and 1 (each within the scatter of the next, the first and the last beyond it); then compound 4.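

For the compounds shown here, replacing vinyl with pentyl on a saturated chain carbon bound to an oxygen next to a carbonyl group gives the first step in this set that changes only one place, and in this assay it is a 2.1-fold higher number from compound 1 to compound 4 (0.33 log units; beyond the scatter). Going by these compounds alone, this shows that the position is not indifferent to what it carries: unlike the earlier compounds, this pair ties a difference in growth inhibition to this one change, with the hexyl compound the weaker inhibitor. The step is modest, however, and it combines two changes. The same difference reads as allyl to hexyl: the chain grows and its double bond is lost.

Which of these two changes matters remains open, and propyl in place of allyl would test the loss of the double bond without the extra length. Nothing measured here explains the step.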